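Fluoro in place of hydrogen: compound 2 to compound 3

This account rests on a few compounds, and the source may have more. Where it says the series, first, only, none or still open, it means among the compounds named here.

Going by the values given here, compound 2 `O=c1[nH]cc(S(=O)(=O)Nc2cccc(-c3cn(-c4ccccc4)nn3)c2)c(=O)[nH]1` carries the only numerical value: in a functional assay on SGC-7901 cells (Homo sapiens) for antiproliferative activity, read by MTT assay, with a stated time of 24 h (a lower number here means a stronger inhibitor, a higher number a weaker inhibitor), compound 2 gives 17200 nM. Compound 1 `O=c1[nH]cc(S(=O)(=O)Nc2ccccc2-c2cn(-c3ccc(F)cc3)nn2)c(=O)[nH]1` returns only a limit in this assay, > 20000 nM. Among the compounds with values here, that limit, (the limit of > 20000 nM in this assay, at which 1 of the 2 values shown sits), is the one further value shown. Compound 3 `O=c1[nH]cc(S(=O)(=O)Nc2cccc(-c3cn(-c4ccc(F)cc4)nn3)c2)c(=O)[nH]1` differs from compound 2 by fluoro in place of hydrogen on an aromatic carbon. Within the data shown here, no measured step covers this change, so in this assay no shift beyond the usual scatter is expected in either direction. Compound 3 is accordingly estimated at 15000 nM, between 6000 nM and 40000 nM, an expected step of a 1.1-fold lower number from compound 2 to compound 3 (0.06 log units; within the scatter).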

Compound 3, half-maximal inhibitory concentration: > 20000 nM
Compound 3: a limit, no number; the forecaster's own chance of this, stated with the estimate: 35%; at least 1.3-fold (0.12 log units) between middle value and limit.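

Going by these compounds alone, the change from phenyl to 4-fluorophenyl, on an aromatic carbon para to a large group, gives the first step, in this assay: an at least 1.1-fold higher number from compound 2 to compound 3 (0.06 log units; that floor lies within the scatter). Compound 3 gives only a limit, > 20000 nM, so the size of this step cannot be read, and its floor does not separate it from the scatter. The limit now holds most of the compounds shown: the limit of > 20000 nM in this assay, at which 2 of the 3 values shown sit.

From the compounds shown here alone, whether fluoro at this position has any real effect remains open. So does whether an amine, a carboxylic acid or a methoxy group in place of that hydrogen would give a lower number than compound 2 does.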